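Swapping a branched chain for a benzyl group

The compounds below may be only part of what the source reports. "The series", "measured", "known", "first", "only" and "open" are said of these compounds alone.

Of the compounds shown here, three built on one shared core have been tested in an assay on Prostate gland for inhibition of steroid 5-alpha-reductase (Rattus norvegicus); on this read-out higher numbers stand for weaker inhibition and lower numbers for stronger inhibition. Compound 1 `CCCCCn1ccc2cc(/C(C)=C/C(=O)Nc3ccccc3OCCCC(=O)O)ccc21` gives 23 nM. Compound 2 `CCC(C)n1ccc2cc(/C(C)=C/C(=O)Nc3ccccc3OCCCC(=O)O)ccc21` gives 67 nM, and compound 3 `CCCC(CC)n1ccc2cc(/C(C)=C/C(=O)Nc3ccccc3OCCCC(=O)O)ccc21` gives 9.3 nM, the lowest of the three numbers. The measured steps are a 2.9-fold higher number from compound 1 to compound 2 (0.46 log units; beyond the scatter), a 2.5-fold lower number from compound 1 to compound 3 (0.39 log units; beyond the scatter) and a 7.2-fold lower number from compound 2 to compound 3 (0.86 log units; beyond the scatter). Compound 4 `C/C(=C\C(=O)Nc1ccccc1OCCCC(=O)O)c1ccc2c(ccn2Cc2cccc(C)c2)c1` differs from compound 3 by 3-methylbenzyl in place of 1-ethylbutyl on an aromatic nitrogen. Going by the values given here, none of the measured steps puts a ring at this position, so they bear only loosely on the change; they show that the group on that nitrogen shifts the number by modest amounts in either direction. A modest rise is therefore expected in this assay, about a 3.2-fold higher number from compound 3 to compound 4 (0.51 log units; beyond the scatter). Compound 4 is estimated at 30 nM, with a range from 10 nM to 90 nM.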

Compound 4, half-maximal inhibitory concentration: 250 nM
Compound 4: the middle estimate sits 8.3-fold (0.92 log units) below what was measured; the whole stated range lies below it.
By their numbers in this assay, from the lowest: compound 3; then compound 1; then compound 2; then compound 4.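

In this assay, 3-methylbenzyl gives a higher number than all three chain groups on this aromatic nitrogen, whether straight or branched (a 27-fold higher number from compound 3 to compound 4 (1.43 log units; beyond the scatter); an 11-fold higher number from compound 1 to compound 4 (1.04 log units; beyond the scatter); a 3.7-fold higher number from compound 2 to compound 4 (0.57 log units; beyond the scatter)). The chains alone had shifted the number only modestly, whereas this change shows that the group here can also move it by a large step. Nothing available explains the rise.

Going by these compounds alone, with only one ring-bearing compound, it stays open whether the ring or its methyl drives the rise. Plain benzyl and cyclohexylmethyl would help to separate the two.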